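Sulfone series: amine substituent change toward compound 4

This account rests on a few compounds, and the source may have more. Where it says the series, first, only, none or still open, it means among the compounds named here.

Compound 3 `COC(=O)[C@H](C)Nc1cc(CS(=O)(=O)/C=C/c2c(OC)cc(OC)cc2OC)ccc1OC` is assessed in a functional assay on DU-145 cells (Homo sapiens) for cytotoxicity, read by trypan blue exclusion, with a stated time of 96 h (on this read-out lower numbers stand for stronger inhibition and higher numbers for weaker inhibition), where compound 3 gives 750 nM. Compound 2 `COc1cc(OC)c(/C=C/S(=O)(=O)Cc2ccc(Br)c(N)c2)c(OC)c1` gives 750 nM in this assay, level with compound 3 within the scatter, and together these two stand as the lowest of the three numbers. Compound 1 `COc1ccccc1/C=C/S(=O)(=O)Cc1ccc(OC)c([N+](=O)[O-])c1` gives 20000 nM in this assay, a higher number than compound 3 and beyond the scatter. Compound 4 `COc1cc(OC)c(/C=C/S(=O)(=O)Cc2ccc(OC)c(NC(F)(F)C(=O)O)c2)c(OC)c1` has not yet been measured. It differs from compound 3 in one place: carboxy(difluoro)methyl in place of 1-(methoxycarbonyl)ethyl on a nitrogen on an aromatic ring. Going by the values given here, no step between measured compounds covers this change. The step of a 2.0-fold higher number from compound 3 to compound 4 (0.30 log units; within the scatter) is expected to be small, toward a somewhat higher number or none beyond the scatter. Compound 4 is estimated at 1500 nM, with a range from 400 nM to 6000 nM.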

Compound 4, half-maximal inhibitory concentration: 150 nM
Estimate against measurement, compound 4: 10-fold (1.00 log units) above; measured number below the stated range.
By their numbers in this assay, from the lowest: compound 4; then compounds 2 and 3 (each within the scatter of the next); then compound 1.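

In this assay, going by these compounds alone, the substituent on this nitrogen proves able to move the read-out: carboxy(difluoro)methyl in place of 1-(methoxycarbonyl)ethyl gives a 5.0-fold lower number from compound 3 to compound 4 (0.70 log units; beyond the scatter) and offers the first step at this position. The change alters several features at once, replacing the ester with a carboxylic acid, adding two fluorines and removing the defined stereocentre. Nothing at hand explains the step.

Which of these features carries the step remains open. A plain carboxymethyl group and the methyl ester of the difluoro acid would separate them.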